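Chain-end variation in a thromboxane synthase inhibitor series

The source may report more compounds than this note shows. Statements on the series, on what has been measured and on what is new or still open speak of the compounds shown alone.

For the measured compounds named here, in an assay (Equus caballus) for inhibition of Thromboxane-A synthase (Homo sapiens), using microsomes (a higher number here means a weaker inhibitor, a lower number a stronger inhibitor), compound 1 `NC(=O)CCCC/C=C(\c1ccccc1)c1cccnc1` gives 400 nM, the highest of the two numbers measured so far; compound 2 `Cc1ccsc1/C(=C/CCCCC(=O)O)c1cccnc1` gives 29 nM, and the gap between these two values lies beyond the scatter. Compound 3 `CC(C)(O)C(CCC/C=C(\c1ccccc1)c1cccnc1)C(=O)O` is not yet measured. It differs from compound 1 by 1-carboxy-2-hydroxy-2-methylpropyl in place of carbamoylmethyl on a saturated chain carbon, three bonds along the chain from a double-bonded chain carbon. Going by the values given here, no measured pair isolates this single change. The expected step from compound 1 to compound 3 is a 5.0-fold lower number from compound 1 to compound 3 (0.70 log units; beyond the scatter), toward a lower number and beyond the scatter. Compound 3 is accordingly estimated at 80 nM, with a range from 20 nM to 320 nM.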

Compound 3, half-maximal inhibitory concentration: 42 nM
For compound 3 the middle estimate is 1.9-fold (0.28 log units) above the measured one; the range from low to high includes it.
By their numbers in this assay, from the lowest: compounds 2 and 3 (each within the scatter of the next); then compound 1.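

In this assay, for the compounds shown here, 1-carboxy-2-hydroxy-2-methylpropyl in place of carbamoylmethyl gives a 9.5-fold lower number from compound 1 to compound 3 (0.98 log units; beyond the scatter), the first step that isolates a single change. This saturated chain carbon, three bonds along the chain from a double-bonded chain carbon, therefore accepts a branched group of 8 heavy atoms in place of one of 4 without loss of inhibition. Nothing available explains the step.

As far as these compounds go, the change replaces the whole group, so the separate shares of the carboxyl, the hydroxy and the methyl branching remain open. From the compounds shown here alone, how a tetrazole or an amine would read at this place is also open.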